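This account rests on a few compounds, and the source may have more. Where it says the series, first, only, none or still open, it means among the compounds named here.

Measured compounds in the series:
Compound 1 `O=C1N=C(N2CCC[C@H]2C(=O)Nc2ccc3ncnc(Nc4cccc(Cl)c4)c3c2)S/C1=C/c1ccc(Br)s1` — in a functional assay on A549 cells (Homo sapiens) for antiproliferative activity, read by MTT assay (a higher number here means a weaker inhibitor, a lower number a stronger inhibitor), compound 1 gives > 50000 nM, which is a limit of the assay and not a number.
Compound 2 `COc1ccc(/C=C2/SC(N3CCC[C@H]3C(=O)Nc3ccc4ncnc(Nc5cccc(Cl)c5)c4c3)=NC2=O)cc1` — in this assay compound 2 gives 31700 nM.

Compound 2 therefore holds the only number shown in this assay; the other value is a limit. The step of an at least 1.5-fold lower number from compound 1 to compound 2 (0.19 log units; that floor lies within the scatter) is within the scatter, so the two measured compounds give no order between them.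

Compound 3 `O=C1N=C(N2CCC[C@H]2C(=O)Nc2ccc3ncnc(Nc4cccc(Cl)c4)c3c2)S/C1=C/c1cccc(Cl)c1` differs from compound 2 by 3-chlorophenyl in place of 4-methoxyphenyl on a double-bonded chain carbon bound to a double-bonded ring carbon. Among the measured compounds shown here, the only measured step bearing on this position is the aryl swap from compound 1 to compound 2, and it was within the scatter, so no step beyond the scatter is expected in this assay here either. The limit of > 50000 nM in this assay, at which 1 of the 2 values shown sits, shows how weak the series sits, so a limit for compound 3 would not surprise. Compound 3 is expected at 38000 nM, range 15000 nM to 100000 nM, which means an expected step of a 1.2-fold higher number from compound 2 to compound 3 (0.08 log units; within the scatter).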

Compound 3, half-maximal inhibitory concentration: > 50000 nM
Compound 3 was reported as a limit; the forecaster's own chance of this, stated with the estimate: 40%; middle value at least 1.3-fold (0.11 log units) away from the limit.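

Replacing 4-methoxyphenyl with 3-chlorophenyl on a double-bonded chain carbon bound to a double-bonded ring carbon gives in this assay an at least 1.5-fold higher number from compound 2 to compound 3 (0.19 log units; that floor lies within the scatter), so this second aryl change also leaves the two compounds without an order. Compound 3 gives > 50000 nM, which is a limit of the assay and not a number. The step between compound 1 and compound 3 cannot be read, and a second aryl group at this position now joins the values at the limit: the limit of > 50000 nM in this assay, at which 2 of the 3 values shown sit.

As far as these compounds go, whether any group at this position gives a value clearly apart from compound 2 remains open. All three compounds carry an aromatic ring here, so an aminoalkyl chain or a carboxylic acid on this carbon is a case on which they give no reading.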